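Chloro for methoxy tried on a longer linker

This account rests on a few compounds, and the source may have more. Where it says the series, first, only, none or still open, it means among the compounds named here.

Compound 1 `COc1ccccc1N1CCN(CCn2nc(N3CCN(C(=O)c4ccco4)CC3)ccc2=O)CC1` and compound 2 `O=C(c1ccco1)N1CCN(c2ccc(=O)n(CCN3CCN(c4ccccc4Cl)CC3)n2)CC1` share one core; compound 3 `COc1ccccc1N1CCN(CCCCCCCn2nc(N3CCN(C(=O)c4ccco4)CC3)ccc2=O)CC1` and compound 4 `O=C(c1ccco1)N1CCN(c2ccc(=O)n(CCCCCCCN3CCN(c4ccccc4Cl)CC3)n2)CC1` share another, and the difference between the two cores is not broken down here. In an assay on cell membranes for binding affinity to Adrenergic receptor alpha-1 (Rattus norvegicus), read by radioligand binding (on this read-out higher numbers stand for weaker inhibition and lower numbers for stronger inhibition), compound 1 gives 94.5 nM, compound 2 gives 34 nM and compound 3 gives 54.7 nM. The change from compound 1 to compound 2 is chloro in place of methoxy on an aromatic carbon, and it brought a 2.8-fold lower number from compound 1 to compound 2 (0.44 log units; beyond the scatter). The same change is made from compound 3 to compound 4, namely (chloro in place of methoxy on an aromatic carbon), at a place described in the same words. In this assay, among the compounds with values here, the step expected from compound 3 to compound 4 is a 2.7-fold lower number from compound 3 to compound 4 (0.44 log units; beyond the scatter), set beside the earlier step because a 2.8-fold lower number from compound 1 to compound 2 (0.44 log units; beyond the scatter) is the only measured instance of this change. Compound 4 is therefore estimated at 20 nM, expected to fall between 8 nM and 50 nM.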

Compound 4, inhibition constant: 5.6 nM
For compound 4 the middle estimate is 3.6-fold (0.55 log units) above the measured one; measured number outside the range, below it.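

In this assay chloro in place of methoxy again lowers the number, this time with a 9.8-fold lower number from compound 3 to compound 4 (0.99 log units; beyond the scatter). The direction of the step carries from one core to the other, but its size does not: the same change on two cores in this assay, a 2.8-fold lower number (0.44 log units; beyond the scatter) from compound 1 to compound 2 and a 9.8-fold lower number (0.99 log units; beyond the scatter) from compound 3 to compound 4, 3.5-fold (0.55 log units) apart, beyond the scatter of two such steps. Two pairs show only that the size of the step can differ from core to core; they do not show which part of the difference between the cores governs it, or how large the step would be on a third core.

Going by these compounds, a propyl or pentyl linker remains open, as does fluoro or bromo in place of chloro. The compounds shown do not tell whether the step changes steadily with chain length or whether the larger step is confined to chloro.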